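This account rests on a few compounds, and the source may have more. Where it says the series, first, only, none or still open, it means among the compounds named here.

Compound 2 `CCCCN(c1nc2c(C(=O)O)cccc2o1)[C@H](C)c1ccc(-c2ccccc2-c2nnn[nH]2)cc1` gives 0.000285 in an ADME assay on the whole organism (plasma, Macaca fascicularis) for protein binding, read by LC-MS, using equilibrium dialysis and cassette dosing, with a stated time of 24 h, at a dose of 1 mg/kg by the oral route (a lower number here means a smaller unbound share, a higher number a larger unbound share of the compound), which stands second highest of the three numbers here. Compound 1 `CCCCN(c1nc2ccccc2o1)[C@H](C)c1ccc(-c2ccccc2-c2nnn[nH]2)cc1` gives 0.000713 in this assay, and compound 3 `Cc1ccc(-c2nc(=O)o[nH]2)c(-c2ccc([C@@H](C)N(CC3CC3)c3nc4c(C(=O)O)cccc4o3)cc2)c1` gives 0.00023, a value within the scatter of compound 2. The step to compound 4 `CCCCN(c1nc2c(CO)cccc2o1)[C@H](C)c1ccc(-c2ccccc2-c2nnn[nH]2)cc1` is hydroxymethyl in place of carboxy on an aromatic carbon. Among the compounds with values here, the one measured step that bears on it is a 2.5-fold lower number from compound 1 to compound 2 (0.40 log units; beyond the scatter), where carboxy replaced hydrogen; removing the carboxy here reverses part of that change. A rise of roughly that order, back toward compound 1, is therefore expected as a 1.8-fold higher number from compound 2 to compound 4 (0.24 log units; within the scatter). Compound 4 is estimated to give 0.0005 in this assay, within a range of 0.00025 to 0.001.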

Compound 4, unbound fraction: 0.00112
Compound 4: the middle estimate sits 2.2-fold (0.35 log units) below what was measured, outside the stated range (above it).
By their numbers in this assay, from the lowest: compounds 3 and 2 (each within the scatter of the next); then compounds 1 and 4 (each within the scatter of the next).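

In this assay, hydroxymethyl in place of carboxy on this aromatic carbon gives a 3.9-fold higher number from compound 2 to compound 4 (0.59 log units; beyond the scatter) and so takes back the whole drop that carboxy brought, not just part of it. Hydroxymethyl in place of hydrogen gives a 1.6-fold higher number from compound 1 to compound 4 (0.20 log units; within the scatter) and stays within the scatter, so among these compounds the lower number goes with carboxy and not with any added group at this carbon. Nothing measured here explains why the two groups differ. Still open, from the compounds shown here alone, is how an amine, an amide or a methyl ester would read at this carbon. Also open, going by these compounds, is whether hydroxymethyl would act the same way on the cyclopropylmethyl compound 3 .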